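Aryl substituent swap on the shared core

The source may hold more compounds than are shown below. What is called first, only, known or untested is meant among the compounds shown, and "the series" means these compounds.

Measured so far:
Compound 1 `CCC1=C(O)c2c(oc(-c3ccc(C)c(C)c3)cc2=O)C(CC)(CC)C1=O`: 0.71 uM
Compound 2 `CCC1=C(O)c2c(oc(-c3ccc(OC)c(F)c3)cc2=O)C(CC)(CC)C1=O`: 0.1 uM

Within the data shown here, in a functional assay on KBVIN cells (Homo sapiens) for antiproliferative activity, read by sulforhodamine B assay, with a stated time of 3 days (a higher number here means that more compound is needed for the effect, a lower number that less compound is needed), compound 2 gives 0.1 uM, the lowest of the two numbers measured; the one measured step is a 7.1-fold lower number from compound 1 to compound 2 (0.85 log units; beyond the scatter).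

Compound 3 `CCC1=C(O)c2c(oc(-c3ccc(F)c(C)c3)cc2=O)C(CC)(CC)C1=O` is not yet measured. The change is 4-fluoro-3-methylphenyl in place of 3-fluoro-4-methoxyphenyl on an aromatic carbon. Among the measured compounds shown here, the only step that bears on it is a 7.1-fold lower number from compound 1 to compound 2 (0.85 log units; beyond the scatter), in which the methoxy and the fluorine entered together and gave the lower number. Compound 3 retains a fluorine and a methyl, each found in one of the measured compounds, but the entering group carries no hydrogen-bond acceptor, so it sits between the two measured compounds in structure, and the data give no way to split the measured step between its two parts.

Compound 3 is therefore expected to give an intermediate number, 0.35 uM (range 0.12 uM to 1 uM), an expected step of a 3.5-fold higher number from compound 2 to compound 3 (0.54 log units; beyond the scatter).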

Compound 3, concentration for half-maximal effect: 1.62 uM
The estimate for compound 3 lay 4.6-fold (0.67 log units) below the measured number, and the stated range ends below it.
By their numbers in this assay, from the lowest: compound 2; then compound 1; then compound 3.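

In this assay, among these compounds, the swap of 3-fluoro-4-methoxyphenyl for 4-fluoro-3-methylphenyl gives a 16-fold higher number from compound 2 to compound 3 (1.21 log units; beyond the scatter) and is the largest step so far, leaving compound 3 with the highest number of the three rather than between the other two. Fluoro in place of methyl on an aromatic carbon gives a 2.3-fold higher number from compound 1 to compound 3 (0.36 log units; beyond the scatter) and so does not lower the number here, which shows that a fluorine on the aryl group does not by itself go with a low number: compound 2 and compound 3 both carry one, yet they stand at the two ends of the series. No accompanying measurement gives a reason for either step.

Still open, going by these compounds, is how much of the low number of compound 2 belongs to the methoxy group and how much to the placing of the fluorine. Also open, on these data alone, is how an ethoxy group, a hydroxy group or an amine would behave on the same aryl ring.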